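This account rests on a few compounds, and the source may have more. Where it says the series, first, only, none or still open, it means among the compounds named here.

Of the compounds shown here, three built on a shared core have been tested in an assay on cells for inhibition of Voltage-dependent T-type calcium channel subunit alpha-1H (Homo sapiens), read by patch clamp; on this read-out lower numbers stand for stronger inhibition and higher numbers for weaker inhibition. Compound 1 `O=C(CC1c2ccccc2N=C(SCCCCCN2CCCC2)N1c1ccc(-c2ccc(F)cc2)cc1)NCc1ccccc1` gives 260 nM. Compound 2 `O=C(CC1c2ccccc2N=C(SCCCCCN2CCCC2)N1c1ccc(-c2ccccc2)cc1)NCc1ccccc1` differs from compound 1 only in that hydrogen stands in place of fluoro on an aromatic carbon. In this assay compound 2 gives 6900 nM; that single change brought a 27-fold higher number from compound 1 to compound 2 (1.42 log units; beyond the scatter). Compound 3 `CN(C)CCCCCSC1=Nc2ccccc2C(CC(=O)NCc2ccccc2)N1c1ccccc1` gives 13800 nM, the highest of the three numbers. Set against compound 2, this number lies within the usual scatter of repeated measurements, so the two cannot be ranked; set against compound 1, the gap is beyond the scatter.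

Compound 4 `O=C(CC1c2ccccc2N=C(SCCCCCN2CCCC2)N1c1ccccc1)NCc1ccccc1` awaits measurement. It differs from compound 3 in one place: pyrrolidin-1-yl in place of dimethylamino on a saturated chain carbon, five bonds along the chain from a sulfur. For the measured compounds named here, none of the measured pairs replaces a dimethylamino group, so no measured step speaks directly to this change; the one measured step concerns a fluoro-to-hydrogen swap on an aromatic ring, a different part of the molecule altogether. With nothing to point either way, the expectation for compound 4 in this assay is a step of no size beyond the scatter, that is a 1.2-fold lower number from compound 3 to compound 4 (0.06 log units; within the scatter). Compound 4 is accordingly estimated at 12000 nM, with an expected range from 4000 nM to 36000 nM.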

Compound 4, half-maximal inhibitory concentration: 7710 nM
Beside the measured number, compound 4's estimate is 1.6-fold (0.19 log units) above it; the range from low to high includes it.
By their numbers in this assay, from the lowest: compound 1; then compounds 2, 4 and 3 (each within the scatter of the next).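

In this assay, pyrrolidin-1-yl in place of dimethylamino on the saturated chain gives a 1.8-fold lower number from compound 3 to compound 4 (0.25 log units; within the scatter) and so cannot be told apart from repeat-measurement noise, which means that these two end groups cannot be ranked on this core. The new compound also reads the aromatic carbon that carries the added ring: hydrogen in place of phenyl gives a 1.1-fold higher number from compound 2 to compound 4 (0.05 log units; within the scatter) with no rankable difference, whereas hydrogen in place of 4-fluorophenyl gives a 30-fold higher number from compound 1 to compound 4 (1.47 log units; beyond the scatter) as a large step, so among the three groups compared there, only 4-fluorophenyl stands apart. No evidence is available on why the two substituents differ so sharply.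

Still open, going by these compounds, is whether the end groups stay interchangeable when 4-fluorophenyl sits on the core, and whether other rings at the chain end, such as piperidin-1-yl or morpholin-4-yl, fit the same picture. On these data alone, it is equally open whether the fluorine itself is special or whether 4-chlorophenyl or 4-methoxyphenyl would stand apart from phenyl in the same way.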